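This account rests on a few compounds, and the source may have more. Where it says the series, first, only, none or still open, it means among the compounds named here.

Measured so far, in a functional assay on MIA PaCa-2 cells (Homo sapiens) for inhibition, read by MTT assay, with a stated time of 7 days; a higher number here means a weaker inhibitor, a lower number a stronger inhibitor:

Compound 1, `CCN(CC)S(=O)(=O)c1ccc(S(=O)(=O)N2CCC[C@@H](C(=O)N3CCC(OC)CC3)C2)cc1` — 140 nM
Compound 2, `CC(C)S(=O)(=O)c1ccc(S(=O)(=O)N2CCC[C@@H](C(=O)N3CCC(F)(F)CC3)C2)cc1` — 11 nM
Compound 3, `CCN(CC)S(=O)(=O)c1ccc(S(=O)(=O)N2CCC[C@@H](C(=O)N3CCS(=O)(=O)CC3)C2)cc1` — 900 nM

Compound 2 gives the lowest number of the three, and its nearest neighbour on the numbers is compound 1, while compound 3 is furthest away; both of those gaps are beyond the usual scatter. For the measured compounds named here, the only single-point change among the measured compounds is the step from compound 1 to compound 3, which changed the ring on the carbonyl carbon: a 6.4-fold higher number from compound 1 to compound 3 (0.81 log units; beyond the scatter).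

Compound 4, `CC(C)NS(=O)(=O)c1ccc(S(=O)(=O)N2CCC[C@@H](C(=O)N3CCC(F)(F)CC3)C2)cc1`, differs from compound 2 at a different place: isopropylamino in place of isopropyl on a sulfonyl sulfur. Going by the values given here, none of the measured steps touches the group on this sulfonyl sulfur, and compound 2 differs from compound 1 in two places at once, so no measured step bears directly on this change. With nothing to point strongly either way, a step in this assay of no more than a modest size, in either direction, is expected; the estimate for compound 4 is 25 nM, with a range from 8 nM to 80 nM, meaning an expected step of a 2.3-fold higher number from compound 2 to compound 4 (0.36 log units; beyond the scatter).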

Compound 4, half-maximal inhibitory concentration: 350 nM
Compound 4: the middle estimate sits 14-fold (1.15 log units) below what was measured; measured number above the stated range.
By their numbers in this assay, from the lowest: compound 2; then compound 1; then compound 4; then compound 3.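

In this assay, for the compounds shown here, the group on this sulfonyl sulfur proves to matter a great deal: isopropylamino in place of isopropyl gives a 32-fold higher number from compound 2 to compound 4 (1.50 log units; beyond the scatter) and is the first measured step at this place. The entering group differs from the one it replaces by only a nitrogen and a hydrogen-bond donor, yet that small difference in the structure goes with a large step in the number. Nothing available here explains this large step.

The compounds shown leave open whether the hydrogen on the new nitrogen or the nitrogen itself goes with the weaker number, a question that a dimethylamino group on this sulfur could help to answer. They also leave open how a simple methyl or a longer chain such as n-butyl in this place would compare with isopropyl.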